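Fluoro for methyl on the pendant phenyl ring

The source may report more compounds than this note shows. Statements on the series, on what has been measured and on what is new or still open speak of the compounds shown alone.

In a functional assay on IMR-32 cells for inhibition of Voltage-dependent N-type calcium channel subunit alpha-1B (Homo sapiens), read by calcium flux (on this read-out higher numbers stand for weaker inhibition and lower numbers for stronger inhibition), compound 3 `CC1=NC(C)=C(C(=O)O)C(c2cccc(C)c2)/C1=C(\O)OC/C=C/c1ccccc1` gives 1800 nM, the lowest number of the three; compound 1 `CC1=NC(C)=C(C(=O)O)C(c2ccc([N+](=O)[O-])cc2)/C1=C(\O)OC/C=C/c1ccccc1` gives 21000 nM and compound 2 `CC1=NC(C)=C(C(=O)O)C(c2cccc(C(=O)O)c2)/C1=C(\O)OC/C=C/c1ccccc1` gives 37000 nM. Both gaps lie beyond the scatter (a 12-fold lower number from compound 1 to compound 3 (1.07 log units; beyond the scatter); a 21-fold lower number from compound 2 to compound 3 (1.31 log units; beyond the scatter)), so compound 3 is the strongest inhibitor measured here, while a 1.8-fold higher number from compound 1 to compound 2 (0.25 log units; within the scatter) stays within the scatter. Compound 4 `CC1=NC(C)=C(C(=O)O)C(c2cccc(F)c2)/C1=C(\O)OC/C=C/c1ccccc1` differs from compound 3 only in fluoro in place of methyl on an aromatic carbon. Among the measured compounds shown here, no measured step swaps methyl for fluoro; the one step at this same aromatic carbon, a 21-fold lower number from compound 2 to compound 3 (1.31 log units; beyond the scatter), concerned a carboxy and was large. Nothing measured tells fluoro from methyl, so only a modest weakening in this assay is expected for compound 4, a 1.7-fold higher number from compound 3 to compound 4 (0.22 log units; within the scatter). Compound 4 is estimated at 3000 nM, between 1000 nM and 9000 nM.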

Compound 4, half-maximal inhibitory concentration: 1300 nM
The estimate for compound 4 lay 2.3-fold (0.36 log units) above the measured number; measured number inside the range.
By their numbers in this assay, from the lowest: compounds 4 and 3 (each within the scatter of the next); then compounds 1 and 2 (each within the scatter of the next).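

In this assay, fluoro and methyl on this aromatic carbon, meta to a large group, cannot be told apart (a 1.4-fold lower number from compound 3 to compound 4 (0.14 log units; within the scatter)). Fluoro shares the large separation from carboxy at the same carbon (a 28-fold lower number from compound 2 to compound 4 (1.45 log units; beyond the scatter)), and 3-fluorophenyl stands well clear of 4-nitrophenyl (a 16-fold lower number from compound 1 to compound 4 (1.21 log units; beyond the scatter)). No supporting data bear on why fluoro and methyl read alike.

Open, from the compounds shown here alone, is whether chloro or methoxy on this carbon would read like fluoro and methyl, or an amine like carboxy. The rest of the shared core stays unchanged across the compounds shown, so its contribution remains open.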